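The source may report more compounds than this note shows. Statements on the series, on what has been measured and on what is new or still open speak of the compounds shown alone.

Measured in a functional assay on CCRF-CEM cells (Homo sapiens); on this read-out higher numbers stand for weaker inhibition and lower numbers for stronger inhibition:

- compound 1 `CN(C)CC1CCC/C(=C\c2ccc(OC(=O)/C=C/c3ccc(Br)cc3)cc2)C1=O`: 4440 nM
- compound 2 `COc1ccc(C(=O)Oc2ccc(/C=C3\CCCCC3=O)cc2)cc1`: 36100 nM
- compound 3 `CN(C)CC1CCC/C(=C\c2ccc(OC(=O)c3ccccc3)cc2)C1=O`: 29400 nM

Compound 3 and compound 2 lie within the usual scatter of each other, so this set cannot put them in order. Both numbers are well above that of compound 1, which means weaker inhibition.

The next compound, compound 4 `COc1ccc(C(=O)Oc2ccc(/C=C3\CCCC(CN(C)C)C3=O)cc2)cc1`, is compound 3 with one small change: methoxy in place of hydrogen on an aromatic carbon, para to a large group, turning phenyl into 4-methoxyphenyl (methoxy in place of hydrogen on an aromatic carbon).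

Among the compounds with values here, only one measured step bears directly on this part of the molecule. It replaces a whole group on the carbonyl carbon, and it gives a 6.6-fold higher number from compound 1 to compound 3 (0.82 log units; beyond the scatter). That step is modest, though beyond the scatter, and it involves a much bigger swap than the one made here. Within the data shown here, no measured step shows methoxy being added on its own. Compound 2, which also carries 4-methoxyphenyl, gives 36100 nM, and this offers no hint of a strong gain.

A change within the scatter therefore seems most likely, with no firm direction. The expected step is a 1.2-fold lower number from compound 3 to compound 4 (0.07 log units; within the scatter). The estimated value for compound 4 is 25000 nM, with an expected range of 10000 nM to 60000 nM.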

Compound 4, half-maximal inhibitory concentration: 5070 nM
Beside the measured number, compound 4's estimate is 4.9-fold (0.69 log units) above it; the whole stated range lies above it.
By their numbers in this assay, from the lowest: compounds 1 and 4 (each within the scatter of the next); then compounds 3 and 2 (each within the scatter of the next).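

In this assay, methoxy in place of hydrogen on the aromatic carbon para to a large group turns out to matter, giving a 5.8-fold lower number from compound 3 to compound 4 (0.76 log units; beyond the scatter), so phenyl and 4-methoxyphenyl are not interchangeable on this scaffold when the (dimethylamino)methyl group is present. The weak result of compound 2 did not carry over to the new compound, since with 4-methoxyphenyl kept in place, (dimethylamino)methyl in place of hydrogen on a saturated ring carbon gives a 7.1-fold lower number from compound 2 to compound 4 (0.85 log units; beyond the scatter), which shows that the 4-methoxyphenyl group can sit in a strong compound. The small 4-methoxyphenyl group also performs on a par with the longer 2-(4-bromophenyl)ethenyl group on the same carbonyl carbon, with a 1.1-fold higher number from compound 1 to compound 4 (0.06 log units; within the scatter), so these two compounds cannot be put in order.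

Nothing available here accounts for why a single methoxy has this effect. Going by these compounds, it remains open whether the methoxy step would be the same size without the (dimethylamino)methyl group, and whether an ethoxy group, a hydroxy group or a chlorine atom at this same aromatic carbon would do as well.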